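Two Weak Binders and a Piperidine Amide Yet to Test

The source may hold more compounds than are shown below. What is called first, only, known or untested is meant among the compounds shown, and "the series" means these compounds.

Compound 1 `CC(C)(C)c1ccc(C(=O)N2CCC3(CC2)C(=O)N(CC(=O)N2CCCC(C(N)=O)C2)CN3c2ccccc2)cc1`: 16900 nM
Compound 2 `CC(C)(C)OC(=O)NCCNC(=O)CN1CN(c2ccccc2)C2(CCN(C(=O)c3ccc(C(C)(C)C)cc3)CC2)C1=O`: 10900 nM
Compound 3 `COC(=O)CCCNC(=O)CN1CN(c2ccccc2)C2(CCN(C(=O)c3ccc(C(C)(C)C)cc3)CC2)C1=O`: "not determined" (no result reported)

Within the data shown here, in an assay on HEK293 cells for displacement of a labelled ligand from NPC1-like intracellular cholesterol transporter 1 (Homo sapiens) (on this read-out lower numbers stand for stronger inhibition and higher numbers for weaker inhibition), compound 1 gives 16900 nM and compound 2 gives 10900 nM; the only one-place step, a 1.6-fold lower number from compound 1 to compound 2 (0.19 log units; within the scatter), stays within the scatter. On this read-out compound 3 gives "not determined" (no result reported), so it stands nowhere on the measured scale. Compound 4 `CC1CCCN(C(=O)CN2CN(c3ccccc3)C3(CCN(C(=O)c4ccc(C(C)(C)C)cc4)CC3)C2=O)C1` differs from it by 3-methylpiperidin-1-yl in place of (3-(methoxycarbonyl)propyl)amino on a carbonyl carbon. Among the measured compounds shown here, no measured step bears directly on this change; the one step known shows that exchanging the group on that carbonyl carbon moved the result little, so compound 4 is expected to fall in the same weak range. Its expected value is 12000 nM, with a range from 3000 nM to 45000 nM.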

Compound 4, half-maximal inhibitory concentration: 12000 nM
Beside the measured number, compound 4's estimate shows no gap at the digits printed, and the stated range covers the measured number.
By their numbers in this assay, from the lowest: compounds 2, 4 and 1 (each within the scatter of the next).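

In this assay, a ring on the carbonyl carbon reads the same as an open chain there: a 1.1-fold higher number from compound 2 to compound 4 (0.04 log units; within the scatter). Removing the carbamoyl from the ring also leaves the result in the same weak range: a 1.4-fold lower number from compound 1 to compound 4 (0.15 log units; within the scatter). Compound 4 thus shows that 3-methylpiperidin-1-yl, with 0 hydrogen-bond donors and 0 hydrogen-bond acceptors, keeps this level without the carbamoyl. Nothing available explains why these groups read alike. Going by these compounds, whether an amine or a carboxylic acid on this carbonyl carbon would move the number beyond the scatter remains open.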